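The source may hold more compounds than are shown below. What is called first, only, known or untested is meant among the compounds shown, and "the series" means these compounds.

Working notes on the series.

Among the compounds with values here, compound 1 `NC(=O)NCCCCN(C[C@H]1Cc2ncccc2CN1)[C@H]1CCCc2cccnc21` is measured in an ADME assay for permeability, using PAMPA, with a stated time of 4 h, at pH 7.4 (a higher number here means that the compound crosses the layer faster, a lower number that the compound crosses the layer more slowly), where compound 1 gives 2 nm/s, the lowest of the three numbers so far. Compound 2 `CCN(CC)CCCCN(C[C@H]1Cc2ncccc2CN1)[C@H]1CCCc2cccnc21` gives 240 nm/s in this assay, and compound 3 `CN(CCCCN(C[C@H]1Cc2ncccc2CN1)[C@H]1CCCc2cccnc21)C1CCC(F)(F)CC1` gives 310 nm/s. The steps from compound 1 are large: a 120-fold higher number from compound 1 to compound 2 (2.08 log units; beyond the scatter), and a 160-fold higher number from compound 1 to compound 3 (2.19 log units; beyond the scatter). Between the two higher compounds, a 1.3-fold higher number from compound 2 to compound 3 (0.11 log units; within the scatter).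

Compound 4 `c1cnc2c(c1)CN[C@@H](CN(CCCC1CCNCC1)[C@H]1CCCc3cccnc31)C2` is not yet measured. Its difference from compound 1: piperidin-4-yl in place of ureidomethyl on a saturated chain carbon, three bonds along the chain from an amine nitrogen. Both measured steps out of compound 1 replace the ureido-bearing end of the chain with an amine-bearing group and both raise the number by a large margin; they bear directly on this step, although neither enters the exact piperidin-4-yl group of compound 4, which carries a hydrogen-bond donor that the entering groups of compound 2 and compound 3 lack. A step upward beyond the scatter is therefore expected, likely smaller than a 120-fold higher number from compound 1 to compound 2 (2.08 log units; beyond the scatter) given that donor.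

Estimate for compound 4 in this assay: 60 nm/s, with a range of 15 nm/s to 200 nm/s, which corresponds to an expected step of a 30-fold higher number from compound 1 to compound 4 (1.48 log units; beyond the scatter).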

Compound 4, apparent permeability: 24 nm/s
Compound 4: middle estimate off by 2.5-fold (0.40 log units), on the high side, within the range that was stated.
By their numbers in this assay, from the lowest: compound 1; then compound 4; then compounds 2 and 3 (each within the scatter of the next).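

Leaving the ureido end of the chain raises the number in this assay even when the entering group is piperidin-4-yl, which still carries a hydrogen-bond donor, with a 12-fold higher number from compound 1 to compound 4 (1.08 log units; beyond the scatter). The amine-bearing end groups at this place are nevertheless not interchangeable: compounds 2 and 3 lie within the scatter of each other, whereas a 10-fold lower number from compound 2 to compound 4 (1.00 log units; beyond the scatter) and a 13-fold lower number from compound 3 to compound 4 (1.11 log units; beyond the scatter) place compound 4 at an intermediate level, well clear of both compound 1 and the higher pair. Nothing measured here accounts for this intermediate level.

The compounds shown leave open whether the gap to compounds 2 and 3 follows the hydrogen on the piperidine nitrogen, the ring itself or the way the ring is attached, as these differ together in the steps above. A 3-(1-methylpiperidin-4-yl)propyl group and a 4-(piperidin-4-yl)butyl group in the same place on the shared core would pull these apart, and a carboxylic acid at the end of the chain would extend the range of end groups beyond the ureido and amine types seen so far.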